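A few compounds are considered here, and "the series" means these few. Any claim that something is new, unique, unknown or untested is made for them only; others in the source may bear on it.

Measured so far in an assay for inhibition of 3-hydroxy-3-methylglutaryl-coenzyme A reductase (Rattus norvegicus); a higher number here means a weaker inhibitor, a lower number a stronger inhibitor:
compound 1 `COC(=O)c1c(C(=O)OC)c(C(C)C)n(CC[C@@H]2C[C@@H](O)CC(=O)O2)c1-c1ccc(F)cc1` gives 180 nM
compound 2 `Cc1c(C)c(C(C)C)n(CC[C@@H]2C[C@@H](O)CC(=O)O2)c1-c1ccc(F)cc1` gives 140 nM
compound 3 `CC(C)c1cc(-c2ccccc2)c(-c2ccc(F)cc2)n1CC[C@@H]1C[C@@H](O)CC(=O)O1` gives 347 nM

Compound 3 has the highest number of the three. Its gap to compound 1 lies within the scatter, so these two cannot be ordered against each other. Its gap to compound 2 lies beyond the scatter, and compound 2 is the stronger inhibitor of that pair.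

Compound 4 `CC(C)c1cc(-c2ccncc2)c(-c2ccc(F)cc2)n1CC[C@@H]1C[C@@H](O)CC(=O)O1` is the next member of the series. Relative to compound 3 it carries pyridin-4-yl in place of phenyl on an aromatic carbon. The shared core of compound 3, the isopropyl group, the 4-fluorophenyl group and the lactone-bearing side chain are kept as they are.

For the measured compounds named here, no pair of measured compounds differs in one place, so nothing directly shows what this exchange does. The exchange is a small one, a single ring atom swapped within a group of the same size, and the three measured compounds all sit within a narrow band of numbers. In this assay a step of no more than the scatter is expected, with at most a slight lean toward a lower number. Compound 4 is estimated at 280 nM, with a range from 110 nM to 700 nM. This corresponds to an expected step of a 1.2-fold lower number from compound 3 to compound 4 (0.09 log units; within the scatter).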

Compound 4, half-maximal inhibitory concentration: 310 nM
Estimate against measurement, compound 4: 1.1-fold (0.04 log units) below, within the range that was stated.
By their numbers in this assay, from the lowest: compounds 2, 1, 4 and 3 (each within the scatter of the next, the first and the last beyond it).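

In this assay the series gains its first exchange in a single place, and it gives a 1.1-fold lower number from compound 3 to compound 4 (0.05 log units; within the scatter). At this position, on the aromatic carbon next to the ring atom that bears a 4-fluorophenyl group, phenyl and pyridin-4-yl therefore cannot be told apart, even though the entering ring carries a hetero atom and one hydrogen-bond acceptor that the leaving ring lacks. No separate measurement on these two compounds accompanies the result, so the data offer no explanation for this reading.

On these data alone, whether the position stays this indifferent to groups of another kind remains open, for instance pyridin-3-yl, with the ring nitrogen placed elsewhere, or a carboxylic acid, an amine or a longer alkyl chain in place of the ring. Compound 1 and compound 2 differ from compound 3 in more than one place, so their steps cannot be read, and the effect of the groups they carry on this carbon and on its neighbouring ring carbon stays unresolved.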